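A Hydroxy Group Added to Compound 3

The source may report more compounds than this note shows. Statements on the series, on what has been measured and on what is new or still open speak of the compounds shown alone.

In a functional assay on ZR-75-1 cells (Homo sapiens) for inhibition, read by sulforhodamine B assay (a higher number here means a weaker inhibitor of growth, a lower number a stronger inhibitor of growth), compound 1 `c1ccc(-c2ccc(-c3ccc(-c4nc5ccccc5[nH]4)cc3)cc2)cc1` gives 100000 nM and compound 2 `COc1ccc(-c2ccc(-c3ccc(-c4nc5cc(C)ccc5[nH]4)cc3)cc2)cc1OC` gives 3100 nM. Compound 3 `Cc1ccc2[nH]c(-c3ccc(-c4ccc(-c5ccccc5)cc4)cc3)nc2c1` gives 27400 nM, the second highest of the three numbers, and its nearest neighbour is compound 1.

Compound 4 `Cc1ccc2[nH]c(-c3ccc(-c4ccc(-c5ccc(O)cc5)cc4)cc3)nc2c1` differs from compound 3 by hydroxy in place of hydrogen on an aromatic carbon, para to a large group, so that phenyl becomes 4-hydroxyphenyl.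

The closest guide is an 8.8-fold higher number from compound 2 to compound 3 (0.95 log units; beyond the scatter), where phenyl replaces 3,4-dimethoxyphenyl. Read in reverse, this suggests that substituting that phenyl could lower the number. The other measured step, a 3.6-fold lower number from compound 1 to compound 3 (0.56 log units; beyond the scatter), shows that adding one small group elsewhere can also move the number beyond the scatter. For the measured compounds named here, no measured compound carries hydroxy, so the guidance is indirect. A modest fall, smaller than the gap to compound 2, is expected, and the estimate is a 3.0-fold lower number from compound 3 to compound 4 (0.48 log units; beyond the scatter). For compound 4 the estimated value is 9000 nM, with an expected range of 2500 nM to 32000 nM.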

Compound 4, concentration for 50% growth inhibition: 18200 nM
Beside the measured number, compound 4's estimate is 2.0-fold (0.31 log units) below it; low and high end bracket the measured number.
By their numbers in this assay, from the lowest: compound 2; then compounds 4 and 3 (each within the scatter of the next); then compound 1.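

In this assay hydroxy on this aromatic carbon, para to a large group, gives a 1.5-fold lower number from compound 3 to compound 4 (0.18 log units; within the scatter) and so does not clearly separate the two compounds. The change from 3,4-dimethoxyphenyl to 4-hydroxyphenyl gives a 5.9-fold higher number from compound 2 to compound 4 (0.77 log units; beyond the scatter) and leaves a gap that lies beyond the scatter. The earlier compounds shown here showed that changing this aryl group could move the number, whereas this result shows that a single hydroxy here does not reach the number of compound 2.

The compounds shown leave open whether a single methoxy group would account for the number of compound 2, and whether an amine or a carboxylic acid on this carbon would move the number beyond the scatter. No available evidence bears on the reason for either step.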